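The source may hold more compounds than are shown below. What is called first, only, known or untested is meant among the compounds shown, and "the series" means these compounds.

Compound 1 `Cc1ccc(NC(=O)COc2ccc3cc(/C=C4/SC(=O)NC4=O)ccc3c2)cc1Cl` gives 1100 nM
Compound 2 `O=C(CN1C(=O)S/C(=C/c2ccccn2)C1=O)Nc1nc2ccccc2s1` gives 9300 nM
Compound 3 `Cc1cc(NC(=O)COc2ccc3cc(/C=C4/SC(=O)NC4=O)ccc3c2)no1` gives 1700 nM

In an assay on isolated protein for inhibition of histone deacetylase 4 (Homo sapiens), with a stated time of 1 h (a higher number here means a weaker inhibitor, a lower number a stronger inhibitor), compound 3 stands second highest of the three numbers; compound 1 is nearest at 1100 nM, within the scatter, and compound 2 is furthest at 9300 nM, beyond it. Compound 4 `O=C(COc1ccc2cc(/C=C3/SC(=O)NC3=O)ccc2c1)Nc1cccc(F)n1` has not yet been measured. It differs from compound 3 only by 6-fluoropyridin-2-yl in place of 5-methyl-1,2-oxazol-3-yl on an amide-type nitrogen. Among the measured compounds shown here, the one measured step at this place is a 1.5-fold higher number from compound 1 to compound 3 (0.19 log units; within the scatter), which exchanges the group on the amide nitrogen without moving the number beyond the scatter. For the measured compounds named here, compound 2 differs in several places at once and shows only that a higher number is possible. The expected step is therefore a 1.1-fold lower number from compound 3 to compound 4 (0.03 log units; within the scatter), with no change beyond the scatter. Compound 4 is estimated at 1600 nM, within 600 nM to 4500 nM.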

Compound 4, half-maximal inhibitory concentration: 840 nM
Compound 4: the middle estimate sits 1.9-fold (0.28 log units) above what was measured; the measured number falls inside the stated range.
By their numbers in this assay, from the lowest: compounds 4, 1 and 3 (each within the scatter of the next, the first and the last beyond it); then compound 2.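

In this assay, the group on the amide-type nitrogen now gives a change just beyond the scatter: 6-fluoropyridin-2-yl in place of 5-methyl-1,2-oxazol-3-yl gives a 2.0-fold lower number from compound 3 to compound 4 (0.31 log units; beyond the scatter) (modest). Exchanged for 3-chloro-4-methylphenyl, the same group gives a 1.3-fold lower number from compound 1 to compound 4 (0.12 log units; within the scatter) and so no change that can be told from the scatter. Nothing measured here explains the step. As far as these compounds go, what a cyclohexyl group or a chain ending in a carboxylic acid would do on this nitrogen stays open. So does the part played by the fluorine, compared with an unsubstituted pyridin-2-yl.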